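This account rests on a few compounds, and the source may have more. Where it says the series, first, only, none or still open, it means among the compounds named here.

Series measured in a functional assay on A549 cells (Homo sapiens) for inhibition, read by MTT assay, with a stated time of 48 h; on this read-out higher numbers stand for weaker inhibition and lower numbers for stronger inhibition:
- compound 1 `Nc1n[nH]c2cccc(-c3cccc(NC(=O)Nc4ccc(F)c(F)c4)c3)c12`: 3040 nM
- compound 2 `CC(C)c1cccc(NC(=O)Nc2cccc(-c3cccc4[nH]nc(N)c34)c2)c1`: 1420 nM
- compound 3 `Nc1n[nH]c2cccc(-c3cccc(NC(=O)Nc4nccs4)c3)c12`: > 500000 nM

Compound 3 stands at the limit of > 500000 nM in this assay, at which 1 of the 3 values shown sits, so its value is a limit and not a number.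

Compound 4 `Nc1n[nH]c2cccc(-c3cccc(NC(=O)Nc4cccc(C(F)(F)F)c4)c3)c12` carries 3-(trifluoromethyl)phenyl in place of 1,3-thiazol-2-yl on an amide-type nitrogen.

The closest evidence is the same exchange run the other way, with a substituted phenyl leaving and 1,3-thiazol-2-yl entering. It gave large steps, an at least 160-fold higher number from compound 1 to compound 3 (2.21 log units; beyond the scatter) and an at least 350-fold higher number from compound 2 to compound 3 (2.54 log units; beyond the scatter). The change between the two phenyl groups was only modest, a 2.1-fold lower number from compound 1 to compound 2 (0.33 log units; beyond the scatter).

A large step to a lower number is therefore expected, estimated as an at least 250-fold lower number from compound 3 to compound 4 (2.39 log units; beyond the scatter).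

For compound 4 the estimated value is 2000 nM, with an expected range of 700 nM to 6000 nM.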

Compound 4, half-maximal inhibitory concentration: 1950 nM
For compound 4 the middle estimate is 1.0-fold (0.01 log units) above the measured one, and the stated range covers the measured number.
By their numbers in this assay, from the lowest: compounds 2, 4 and 1 (each within the scatter of the next, the first and the last beyond it). At a limit, above all of these: compound 3.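

In this assay, a third substituted phenyl on the amide-type nitrogen again stands far from 1,3-thiazol-2-yl, with an at least 250-fold lower number from compound 3 to compound 4 (2.40 log units; beyond the scatter), so the gap no longer rests on two phenyl groups alone. The phenyl groups themselves are not told apart, with a 1.4-fold higher number from compound 2 to compound 4 (0.14 log units; within the scatter) and a 1.6-fold lower number from compound 1 to compound 4 (0.19 log units; within the scatter), so trifluoromethyl and isopropyl give no separable result here. Compound 3 remains a limit and not a number: the limit of > 500000 nM in this assay, at which 1 of the 4 values shown sits.

As far as these compounds go, what a phenyl carrying an amine or a carboxylic acid would give on this nitrogen stays open. Also open, from the compounds shown here alone, is whether a five-membered aromatic ring other than 1,3-thiazol-2-yl would reach the same limit.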